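Bromo substitution on the fused ring of compound 2

A few compounds are considered here, and "the series" means these few. Any claim that something is new, unique, unknown or untested is made for them only; others in the source may bear on it.

Two compounds of this series carry measured numbers in a functional assay on cells (Cancer cell lines, Homo sapiens) for cytotoxicity, read by sulforhodamine B assay, with a stated time of 48 h; a higher number here means a weaker inhibitor of growth, a lower number a stronger inhibitor of growth. Compound 1 `COc1ccc(C2=NN(C3=NC(=O)/C(=C4\C(=O)Nc5ccc(Br)cc54)S3)C(c3ccc(OC)cc3)C2)cc1` gives 270 nM in this assay. Compound 2 `COc1ccc(C2=NN(C3=NC(=O)/C(=C4\C(=O)Nc5ccccc54)S3)C(c3ccc(Cl)cc3)C2)cc1` gives 100000 nM in this assay, the highest of the two numbers; its nearest neighbour is compound 1, which sits far lower, a gap beyond the scatter. Among the measured compounds shown here, the two differ in more than one place, so no single step is drawn between them.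

Compound 3 `COc1ccc(C2=NN(C3=NC(=O)/C(=C4\C(=O)Nc5ccc(Br)cc54)S3)C(c3ccc(Cl)cc3)C2)cc1` is not yet measured. Relative to compound 2 the change is bromo in place of hydrogen on an aromatic carbon. For the measured compounds named here, compound 1, which carries the same bromo on its fused ring, gives 270 nM, whereas compound 2 lacks it; compound 1 and compound 3 also differ elsewhere, so there is no direct precedent for this exact pairing. The change from compound 2 to compound 3 is nonetheless expected to lower the number by a large step, well beyond the scatter, with considerable uncertainty about its size. The expected step is a 33-fold lower number from compound 2 to compound 3 (1.52 log units; beyond the scatter). Compound 3 is expected to give about 3000 nM in this assay, within a range from 300 nM to 40000 nM.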

Compound 3, concentration for 50% growth inhibition: 180 nM
For compound 3 the middle estimate is 17-fold (1.22 log units) above the measured one, outside the stated range (below it).
By their numbers in this assay, from the lowest: compounds 3 and 1 (each within the scatter of the next); then compound 2.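

With the chloro group held constant, the change from hydrogen to bromo on an aromatic carbon of the fused system can now be read as a change in one place, and in this assay it gives a 560-fold lower number from compound 2 to compound 3 (2.74 log units; beyond the scatter) and stands as a large step at this position. With bromo present in both compounds, chloro in place of methoxy on an aromatic carbon gives a 1.5-fold lower number from compound 1 to compound 3 (0.18 log units; within the scatter) and remains within the scatter, so this second change does not separate this bromo pair in this assay and shows no effect comparable with that of the bromo step. No measurement shown here accounts for the size of the bromo step.

Going by these compounds, the bromo step is read only in the chloro-bearing pair, so its size with methoxy in place of chloro remains open. On these data alone, it is also open whether fluoro, a nitrile, or an amine on the same aromatic carbon would track bromo in this assay or fall back towards the hydrogen compound, compound 2.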